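Solubility of a biaryl analogue in a quinoline-based series

The source may report more compounds than this note shows. Statements on the series, on what has been measured and on what is new or still open speak of the compounds shown alone.

Measured so far:
- compound 1 `COc1ccc(F)cc1CNCCCNc1ccnc2cc(CC(C)C)ccc12`, 4200 nM
- compound 2 `COc1ccc(F)cc1CNCCCNc1ccnc2cc(Cc3ccc(F)cc3Cl)ccc12`, 4200 nM
- compound 3 `COc1cccc(CNCCCNc2ccnc3cc(Cc4ccc(F)cc4Cl)ccc23)c1O`, 4200 nM

In a physicochemical assay for solubility, with a stated time of 18 h, at pH 7.4 (on this read-out lower numbers stand for lower solubility and higher numbers for higher solubility), compound 2 gives 4200 nM, level with compound 1 and compound 3 at the digits shown. The step of no change at the digits printed from compound 1 to compound 2 (within the scatter) and the step of no change at the digits printed from compound 2 to compound 3 (within the scatter) both stayed within the scatter, so neither change in the side groups moved the read-out. Compound 4 `COc1ccc(F)cc1CNCCCNc1ccnc2cc(-c3ccc(C(F)(F)F)cc3)ccc12` carries a different change: 4-(trifluoromethyl)phenyl in place of 2-chloro-4-fluorobenzyl on an aromatic carbon. Going by the values given here, no measured step tests a ring attached directly to the core in this way, so the earlier flat steps are only loosely informative. A modest drop in this assay is expected, giving a 1.7-fold lower number from compound 2 to compound 4 (0.23 log units; within the scatter). Compound 4 is therefore estimated at 2500 nM, with a range from 900 nM to 5500 nM.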

Compound 4, solubility: 32000 nM
Compound 4: the middle estimate sits 13-fold (1.11 log units) below what was measured, outside the stated range (above it).
By their numbers in this assay, from the lowest: compounds 1, 2 and 3 (each within the scatter of the next); then compound 4.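

In this assay this position turns out to respond to the group it carries: the change to 4-(trifluoromethyl)phenyl gives a 7.6-fold higher number from compound 2 to compound 4 (0.88 log units; beyond the scatter) and, against the isobutyl group, a 7.6-fold higher number from compound 1 to compound 4 (0.88 log units; beyond the scatter) on the same aromatic carbon. The earlier groups at this position, both joined through a saturated carbon, sat level, whereas this ring is attached directly to the core. Nothing available explains the rise.

Going by these compounds, it remains open whether the direct attachment or the trifluoromethyl group matters more, and whether a directly attached plain phenyl or a phenyl bearing a carboxylic acid would behave alike.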